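This account rests on a few compounds, and the source may have more. Where it says the series, first, only, none or still open, it means among the compounds named here.

Measured so far in an assay on isolated protein for inhibition of leukotriene B4 receptor 1 (Homo sapiens), tested at 10 uM; on this read-out lower numbers stand for less inhibition and higher numbers for more inhibition at the one concentration tested (going by the name of the read-out):
compound 1 `CCCCCc1cc(C(C)=O)c(O)cc1OCCCCC#N` gives 31%;
compound 2 `CCCCCCc1cc(C(C)=O)c(O)cc1OCCCCC#N` gives 51%;
compound 3 `C=CCc1cc(C(C)=O)c(O)cc1OCCCCC` gives 60%.

Compound 1 and compound 2 differ by methyl in place of hydrogen on a saturated chain carbon, five bonds along the chain from an aromatic carbon, and this step gave a number 20 percentage points higher from compound 1 to compound 2 (beyond the scatter). Among the compounds with values here, compound 3 stands highest of the three numbers so far, though its gap to compound 2 lies within the scatter; only its gap to compound 1 lies beyond it. The difference between the core of compound 1 and the core of compound 3 is not broken down here.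

Compound 4 `C=CCc1cc(C(C)=O)c(O)cc1OCCCCCC` is not yet measured. It differs from compound 3 by methyl in place of hydrogen on a saturated chain carbon, five bonds along the chain from an oxygen on an aromatic ring. This is the same kind of change as from compound 1 to compound 2, but not the same: there the place was five bonds along the chain from an aromatic carbon, here it is five bonds along the chain from an oxygen on an aromatic ring. The change is seen once among measured compounds, so the expected step in this assay rests on a single pair and on a different chain. Given the rise from compound 1 to compound 2 of a number 20 percentage points higher from compound 1 to compound 2 (beyond the scatter), a smaller rise is estimated from compound 3 to compound 4, a number 10 percentage points higher from compound 3 to compound 4 (within the scatter). Compound 4 is therefore expected to give about 70% in this assay, estimated between 52% and 86%.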

Compound 4, a percentage reported as inhibition, at one concentration (the size of the read-out at that concentration, not a potency): 50%
Compound 4: middle estimate off by 20 percentage points, on the high side, outside the stated range (below it).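

In this assay the added methyl gives a number 10 percentage points lower from compound 3 to compound 4 (within the scatter). Set beside the earlier step, this change does not carry over as a fixed increment from one core to the other in this series: the same change on two cores in this assay, a number 20 percentage points higher (beyond the scatter) from compound 1 to compound 2 and a number 10 percentage points lower (within the scatter) from compound 3 to compound 4, 30 percentage points apart, beyond the scatter of two such steps. With one pair on each core, and with the methyl added to a different chain in each pair, this does not show whether the core or the place of the change accounts for the gap.

The compounds shown leave open how the inhibition responds to a longer chain on the aromatic oxygen of compound 4. Also open, going by these compounds, is what a carboxylic acid in place of the nitrile of compound 2 would give.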